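Shortening the amine-bearing chain on two related cores

This account rests on a few compounds, and the source may have more. Where it says the series, first, only, none or still open, it means among the compounds named here.

Compound 1 `CCN(CC)CCCNc1nc(-c2ccc(NC(=O)Nc3ccc(F)cc3)cc2)nc2c(Cl)c(Cl)sc12` and compound 3 `CCN(CC)CCNc1nc(-c2ccc(NC(=O)Nc3ccc(F)cc3)cc2)nc2c(Cl)c(Cl)sc12` share one core and differ by diethylamino in place of (diethylamino)methyl on a saturated chain carbon, two bonds along the chain from a nitrogen on an aromatic ring. In a functional assay on HT-29 cells (Homo sapiens) for cytotoxicity, read by MTT assay, with a stated time of 72 h (on this read-out higher numbers stand for weaker inhibition and lower numbers for stronger inhibition), compound 1 gives 350 nM, and compound 3 gives 650 nM, a step of a 1.9-fold higher number from compound 1 to compound 3 (0.27 log units; within the scatter). Compound 2 `CCN(CC)CCCNc1nc(-c2ccc(NC(=O)Nc3ccccc3F)cc2)nc2ccsc12` carries a different core; the difference between the two cores is not broken down here. In this assay compound 2 gives 550 nM. Compound 4 `CCN(CC)CCNc1nc(-c2ccc(NC(=O)Nc3ccccc3F)cc2)nc2ccsc12` is not yet measured; it differs from compound 2 by diethylamino in place of (diethylamino)methyl on a saturated chain carbon, two bonds along the chain from a nitrogen on an aromatic ring, the same change as that from compound 1 to compound 3. The expected step is a 1.8-fold higher number from compound 2 to compound 4 (0.26 log units; within the scatter), resting on the step of a 1.9-fold higher number from compound 1 to compound 3 (0.27 log units; within the scatter) seen on the other core. Compound 4 is therefore estimated at 1000 nM, with a range of 500 nM to 2200 nM.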

Compound 4, half-maximal inhibitory concentration: 610 nM
Compound 4: middle estimate off by 1.6-fold (0.21 log units), on the high side; measured number inside the range.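

Going from (3-(diethylamino)propyl)amino to (2-(diethylamino)ethyl)amino on the core of compound 2 gives, in this assay, a 1.1-fold higher number from compound 2 to compound 4 (0.04 log units; within the scatter). Set beside the earlier step on the other core, the change reads alike on both: the same change on two cores in this assay, a 1.9-fold higher number (0.27 log units; within the scatter) from compound 1 to compound 3 and a 1.1-fold higher number (0.04 log units; within the scatter) from compound 2 to compound 4, 1.7-fold (0.22 log units) apart, within the scatter of two such steps. So the change carries over between these two cores without a difference that can be told apart, but each step lies within the scatter on its own, so this does not show that the shorter chain alters the number at all, and two cores cannot speak for the whole series.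

From the compounds shown here alone, whether a longer chain, or a ring amine such as morpholine in place of diethylamino, would move the number beyond the scatter stays open. So does how this change behaves on further cores.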